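The compounds below may be only part of what the source reports. "The series", "measured", "known", "first", "only" and "open" are said of these compounds alone.

Of the compounds shown here, three on a shared core have been measured in an ADME assay on BJ cells (Homo sapiens) for cytotoxicity, with a stated time of 72 h; a higher number here means that more compound is needed for the effect, a lower number that less compound is needed. Compound 1 `CCc1ccc(-c2nc3c(c(C)nn3-c3ccccc3)c(-c3ccccc3F)c2C#N)cc1` gave no number, only a limit of > 20000 nM. Compound 2 `Cc1ccccc1-c1nc2c(c(C)nn2-c2ccccc2)c(-c2ccccc2O)c1C#N` gives 21000 nM, and compound 3 `Cc1nn(-c2ccccc2)c2nc(-c3ccc(C(C)C)cc3)c(C#N)c(-c3ccccc3O)c12` gives 22600 nM. Those two numbers lie close to the limit of > 20000 nM in this assay, at which 1 of the 3 values shown sits, and within the scatter of each other, so compound 3 stands level with compound 2 on the values shown.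

The next compound, compound 4 `Cc1nn(-c2ccccc2)c2nc(-c3ccc(Cl)cc3)c(C#N)c(-c3ccccc3O)c12`, differs from compound 3 by chloro in place of isopropyl on an aromatic carbon, para to a large group. For the measured compounds named here, only one measured step bears on this change. It is a 1.1-fold higher number from compound 2 to compound 3 (0.03 log units; within the scatter), with 4-isopropylphenyl in place of 2-methylphenyl on an aromatic carbon. Going by the values given here, that step brought no change beyond the scatter, although it is a single comparison and none of the measured compounds carries the chloro group. On this evidence, no step beyond the scatter is expected in this assay, and the direction is left open. The expected move is a 1.1-fold lower number from compound 3 to compound 4 (0.05 log units; within the scatter). Among the compounds with values here, a result reported only as a limit would also be no surprise for this compound. For compound 4 the estimate is 20000 nM, with an expected range from 10000 nM to 38000 nM.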

Compound 4, half-maximal effective concentration: > 20000 nM
Compound 4: a limit, no number (the forecaster's own chance of this, stated with the estimate: 30%); the middle value lies on the limit itself.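

In this assay compound 4 gives only a limit, > 20000 nM. For the compounds shown here, its steps from compound 2 and from compound 3 cannot be read, so this result yields no new step. The compounds shown leave open what number, if any, the 4-chlorophenyl compound would give, and the values offer little room for comparison: the limit of > 20000 nM in this assay, at which 2 of the 4 values shown sit.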